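The source may report more compounds than this note shows. Statements on the series, on what has been measured and on what is new or still open speak of the compounds shown alone.

- compound 1 `CN1C[C@H](C(=O)Nc2ccc(F)cc2)[C@@H](c2ccc(/C=C/C(=O)Nc3ccccc3N)cc2)C1` at 34 mL/min/kg
- compound 2 `CN1C[C@H](C(=O)Nc2cccnc2)[C@@H](c2ccc(/C=C/C(=O)Nc3ccccc3N)cc2)C1` at 41 mL/min/kg

Both values come from an in vitro ADME assay on microsomes from liver (Mus musculus) for pharmacokinetics, read by LC-MS, with a stated time of 10 min, tested at 1 uM (a higher number here means faster removal of the compound, a lower number slower removal), and compound 2 stands level with compound 1 within the scatter. Compound 3 `CN1C[C@H](C(=O)NC2CCCC2)[C@@H](c2ccc(/C=C/C(=O)Nc3ccccc3N)cc2)C1` has cyclopentyl in place of pyridin-3-yl on an amide-type nitrogen. Among the compounds with values here, the one measured step at this place is a 1.2-fold higher number from compound 1 to compound 2 (0.08 log units; within the scatter) and no measured compound holds a non-aromatic ring there. On that single small step, no change beyond the scatter is expected in this assay, and the estimated step is a 1.1-fold higher number from compound 2 to compound 3 (0.04 log units; within the scatter) with wide uncertainty. For compound 3 the expected clearance is 45 mL/min/kg within an estimated range of 22 mL/min/kg to 90 mL/min/kg for now.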

Compound 3, clearance: 61 mL/min/kg
The estimate for compound 3 lay 1.4-fold (0.13 log units) below the measured number; low and high end bracket the measured number.
By their numbers in this assay, from the lowest: compounds 1, 2 and 3 (each within the scatter of the next).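

Cyclopentyl brings a non-aromatic ring of carbon only onto the amide-type nitrogen, and this assay gives a 1.5-fold higher number from compound 2 to compound 3 (0.17 log units; within the scatter) and a 1.8-fold higher number from compound 1 to compound 3 (0.25 log units; within the scatter). At this position, all three rings shown therefore stand within the scatter of one another, whether aromatic or not. No available evidence bears on the reason for these numbers.

Still open, from the compounds shown here alone, is whether a piperidine ring bearing a basic amine, a carboxylic acid or a longer alkyl chain on this nitrogen would take clearance beyond the scatter. Going by these compounds, whether changes elsewhere on the shared core would do so also remains open.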